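Swapping methylamino for methyl in compound 1

This account rests on a few compounds, and the source may have more. Where it says the series, first, only, none or still open, it means among the compounds named here.

In a functional assay on HCT-116 cells (Homo sapiens), read by MTT assay, with a stated time of 72 h (a higher number here means a weaker inhibitor, a lower number a stronger inhibitor), compound 1 `CNc1ncnc2c1c(-c1ccoc1)cn2[C@@H]1O[C@H](CO)[C@@H](O)[C@H]1O` gives > 20000 nM, which is a limit and not a number. Compound 2 `CNc1ncnc2c1c(-c1cccs1)cn2[C@@H]1O[C@H](CO)[C@@H](O)[C@H]1O`, with thiophen-2-yl in place of furan-3-yl, gives > 20000 nM, which is also a limit. The record so far is therefore (the limit of > 20000 nM in this assay, at which 2 of the 2 values shown sit). Among the measured compounds shown here, the only measured change is a step that the two limits leave unreadable from compound 1 to compound 2, so it offers no size to carry forward.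

Compound 3 `Cc1ncnc2c1c(-c1ccoc1)cn2[C@@H]1O[C@H](CO)[C@@H](O)[C@H]1O` keeps furan-3-yl and has methyl in place of methylamino on an aromatic carbon. For the measured compounds named here, no measured step touches this change. Since compound 1 gives only a limit, any readable result in this assay would have to show stronger inhibition, though compound 3 may well remain unreadable too. The expected step is an at least 5.0-fold lower number from compound 1 to compound 3 (0.69 log units; beyond the scatter), a tentative estimate. Compound 3 is expected at about 4000 nM, with an estimated range of 400 nM to 20000 nM.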

Compound 3, half-maximal inhibitory concentration: > 20000 nM
Compound 3 was reported as a limit; the forecaster's own chance of this, stated with the estimate: 35%; at least 5.0-fold (0.69 log units) between middle value and limit.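

Compound 3 and compound 1 are both reported only as limits in this assay, so the step between them cannot be read, and the record stays where it was: the limit of > 20000 nM in this assay, at which 3 of the 3 values shown sit.

The compounds shown leave open whether methyl in place of methylamino changes inhibition at all, and by how much.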